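A few compounds are considered here, and "the series" means these few. Any claim that something is new, unique, unknown or untested is made for them only; others in the source may bear on it.

In a functional assay on CCRF-CEM cells (Homo sapiens) for antiproliferative activity, read by MTT assay, with a stated time of 48 h, tested at 25 uM (a lower number here means a stronger effect, a higher number a weaker effect of the compound at the concentration tested), compound 1 `OC(CCn1nc2c(Br)c(Br)c(Br)c(Br)c2n1)c1cccc(Br)c1` gives 54%.
In this assay compound 2 `COc1cccc(C(O)CCn2nc3c(Br)c(Br)c(Br)c(Br)c3n2)c1` gives 50%.
In this assay compound 3 `C[C@@H](O)CCn1nc2c(Br)c(Br)c(Br)c(Br)c2n1` gives 71%.

Compound 2 shows the lowest of these three numbers: compound 1 sits within the scatter of it, while compound 3 stands apart, beyond the scatter. Compound 4 `OC(CCn1nc2c(Br)c(Br)c(Br)c(Br)c2n1)c1ccccc1` differs from compound 2 by one change: hydrogen in place of methoxy on an aromatic carbon. Going by the values given here, the only measured step at that place is a number 4 percentage points lower from compound 1 to compound 2 (within the scatter), which stayed within the scatter, so swapping one small group for another there has so far left the read-out essentially unchanged. Among the compounds with values here, no measured step removes such a group altogether. Compound 4 is therefore expected to show only a number 5 percentage points higher from compound 2 to compound 4 (within the scatter) in this assay. The estimate for compound 4 is 55%, from 40% to 70%.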

Compound 4, a percentage reported as activity, at one concentration (the size of the read-out at that concentration, not a potency): 84%
Estimate against measurement, compound 4: 29 percentage points below; the measured number lies above the stated range.
By their numbers in this assay, from the lowest: compounds 2 and 1 (each within the scatter of the next); then compound 3; then compound 4.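

In this assay hydrogen in place of methoxy gives a number 34 percentage points higher from compound 2 to compound 4 (beyond the scatter) and hydrogen in place of bromo gives a number 30 percentage points higher from compound 1 to compound 4 (beyond the scatter) and so this ring carbon is sensitive after all. Exchanging one of these two groups for the other left the read-out within the scatter, while removing either one weakens the effect at the concentration tested. Nothing measured here explains this difference. On these data alone, whether an amine, a carboxylic acid or a fluorine atom on this carbon would also keep the stronger effect remains open. So does whether methoxy would do the same on another carbon of this ring.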